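This account rests on a few compounds, and the source may have more. Where it says the series, first, only, none or still open, it means among the compounds named here.

In a functional assay on IGROV-1 cells (Homo sapiens) for cytotoxicity, read by sulforhodamine B assay, with a stated time of 48 h, tested at 0.1 uM (on this read-out higher numbers stand for a weaker effect at the one concentration tested and lower numbers for a stronger effect), compound 2 `COc1ccc(-c2cc(/C=C/C(=O)c3ccc(N)cc3)[nH]n2)cc1OC` gives 106%, while compound 1 `COc1ccc(-c2cc(/C=C/C(=O)c3ccc(N)cc3)[nH]n2)cc1` gives 91%. The change between them, (hydrogen in place of methoxy on an aromatic carbon), produced a step of a number 15 percentage points lower from compound 2 to compound 1 (beyond the scatter). Compound 3 `COc1cc(C(=O)/C=C/c2cc(-c3cc(OC)c(OC)c(OC)c3)n[nH]2)cc(OC)c1OC` shows 103% in this assay; the difference between the core of compound 3 and that of compound 2 is not broken down here. Compound 4 `COc1ccc(-c2cc(/C=C/C(=O)c3cc(OC)c(OC)c(OC)c3)[nH]n2)cc1OC` has not yet been measured. It differs from compound 3 by hydrogen in place of methoxy on an aromatic carbon, the same kind of change as that leading to compound 1, though here the place is also meta to a methoxy group. A step of comparable size is expected, a number 13 percentage points lower from compound 3 to compound 4 (beyond the scatter), because the earlier step was a number 15 percentage points lower from compound 2 to compound 1 (beyond the scatter). Compound 4 is therefore estimated at 90%, within a range from 75% to 105%.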

Compound 4, a percentage reported as activity, at one concentration (the size of the read-out at that concentration, not a potency): 97%
For compound 4 the middle estimate is 7 percentage points below the measured one, and the stated range covers the measured number.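

In this assay, putting hydrogen in place of methoxy on an aromatic carbon of the core of compound 3 gives a number 6 percentage points lower from compound 3 to compound 4 (within the scatter). Set beside the earlier case, the two steps do not differ: the same change on two cores in this assay, a number 15 percentage points lower (beyond the scatter) from compound 2 to compound 1 and a number 6 percentage points lower (within the scatter) from compound 3 to compound 4, 9 percentage points apart, within the scatter of two such steps. Among these compounds, the change can thus be carried between these two cores without a detectable difference in step size, but this rests on only two pairs at one concentration, and the second step alone cannot be told from scatter, so it shows neither a general rule nor anything about potency.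

The compounds shown leave open how a hydroxy group, a fluorine atom or a longer chain such as ethoxy would read at that aromatic carbon in this assay. They also leave open whether the comparison of the two steps would hold at other concentrations.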